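Shifting the Methoxy Group on the Pendant Ring

The source may report more compounds than this note shows. Statements on the series, on what has been measured and on what is new or still open speak of the compounds shown alone.

Compound 2, `CCCS(=O)(=O)Nc1ccc(F)c(C(=O)c2n[nH]c3ncc(-c4ccccc4OC)cc23)c1F`, and compound 1, `CCCS(=O)(=O)Nc1ccc(F)c(C(=O)c2n[nH]c3ncc(-c4ccc(F)cc4)cc23)c1F`, share one core and differ only in the ring hanging from it. In an assay for binding affinity to dual specificity mitogen-activated protein kinase kinase 4 (Homo sapiens), read by KINOMEscan, tested at 100 nM (on this read-out higher numbers stand for a weaker effect at the one concentration tested and lower numbers for a stronger effect), compound 1 gives 2.1%, and compound 2 gives 1.9%. Compound 2 stands at the lower of the two numbers shown, but the step of a number 0.2 percentage points lower from compound 1 to compound 2 (within the scatter) lies within the scatter, so the two count as alike, both binding strongly at this concentration. Compound 3, `CCCS(=O)(=O)Nc1ccc(F)c(C(=O)c2n[nH]c3ncc(-c4ccc(OC)cc4)cc23)c1F`, differs from compound 2 by 4-methoxyphenyl in place of 2-methoxyphenyl on an aromatic carbon. Within the data shown here, no measured step tests exactly this change; the one step at hand, a number 0.2 percentage points lower from compound 1 to compound 2 (within the scatter), exchanged one pendant ring for a quite different one and produced nothing beyond the scatter. On that basis the expected step is a number 0.6 percentage points higher from compound 2 to compound 3 (within the scatter), that is, no change beyond the scatter. Compound 3 is therefore estimated at 2.5%, within a range from 0.5% to 15%.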

Compound 3, a percentage reported as activity, at one concentration (the size of the read-out at that concentration, not a potency): 4.2%
Estimate against measurement, compound 3: 1.7 percentage points below; the measured number falls inside the stated range.
By their numbers in this assay, from the lowest: compounds 2, 1 and 3 (each within the scatter of the next).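

Moving the methoxy group around the pendant ring, with 4-methoxyphenyl in place of 2-methoxyphenyl, gives a number 2.3 percentage points higher from compound 2 to compound 3 (within the scatter) in this assay and so shows no effect of the group's place on this ring that can be told apart from the scatter. Methoxy in place of fluoro on the same ring gives a number 2.1 percentage points higher from compound 1 to compound 3 (within the scatter) and likewise leaves these two groups alike on this read-out, so all three pendant rings shown count as equal here. Nothing available explains why these rings give such similar numbers.

On these data alone, whether a pendant ring carrying an amine or a carboxylic acid would shift the number beyond the scatter remains open. A reading at one concentration is not a potency, so any difference in potency among these three compounds also remains open.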